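Halogen swap on the pendant phenyl, two measured analogues

A few compounds are considered here, and "the series" means these few. Any claim that something is new, unique, unknown or untested is made for them only; others in the source may bear on it.

Measured so far:
compound 1, `Oc1ccccc1/C=N/c1nnc(SCc2nnc(-c3ccccc3)o2)s1`, 9760 nM
compound 2, `Oc1ccccc1/C=N/c1nnc(SCc2nnc(-c3ccc(F)cc3)o2)s1`, 15600 nM

In a functional assay on MCF7 cells (Homo sapiens) for inhibition, read by CCK-8 assay (a higher number here means a weaker inhibitor, a lower number a stronger inhibitor), compound 1 gives 9760 nM, and compound 2 gives 15600 nM. Among the compounds with values here, the only measured step, a 1.6-fold higher number from compound 1 to compound 2 (0.20 log units; within the scatter), leaves the two compounds undistinguished on this assay; compound 2 is therefore not separated from compound 1 by anything beyond the scatter.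

Compound 3, `Oc1ccccc1/C=N/c1nnc(SCc2nnc(-c3ccccc3Cl)o2)s1`, is the next member. Relative to compound 2 the change is 2-chlorophenyl in place of 4-fluorophenyl on an aromatic carbon. Within the data shown here, no measured step covers a 2-chlorophenyl group, so the only point of reference is the fluoro-for-hydrogen step from compound 1 to compound 2, which stayed within the scatter. On that basis the swap is expected to move this assay little; the estimated step from compound 2 to compound 3 is a 1.3-fold lower number from compound 2 to compound 3 (0.11 log units; within the scatter), with no direction claimed beyond the scatter. Compound 3 is expected to give about 12000 nM, within a range of 5000 nM to 30000 nM.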

Compound 3, half-maximal inhibitory concentration: 18100 nM
Estimate against measurement, compound 3: 1.5-fold (0.18 log units) below; measured number inside the range.
By their numbers in this assay, from the lowest: compounds 1, 2 and 3 (each within the scatter of the next).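

In this assay the replacement of 4-fluorophenyl by 2-chlorophenyl gives a 1.2-fold higher number from compound 2 to compound 3 (0.06 log units; within the scatter), and adding a chloro group to the unsubstituted phenyl gives a 1.9-fold higher number from compound 1 to compound 3 (0.27 log units; within the scatter); both steps lie within the scatter. Compound 2 alone offered one halogen on the pendant phenyl, whereas compound 3 adds a second halogen at a different place on that ring, and the three compounds still cannot be told apart on this read-out. Within these three compounds, then, neither halogen separates from the unsubstituted phenyl, and no evidence at hand bears on why the numbers stay together.

In the step from compound 2 to compound 3 the halogen and its place on the phenyl change together, so the contribution of each stays unresolved. Also open, as far as these compounds go, is whether a group of another kind on the phenyl, such as an amine, a carboxylic acid or a longer chain, would give a step beyond the scatter in this assay and so show that this part of the structure matters for the number.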